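The source may hold more compounds than are shown below. What is called first, only, known or untested is meant among the compounds shown, and "the series" means these compounds.

Measured so far:
- compound 1 `COC(CCn1cnc2c(NCc3ccc(C(=O)Nc4ccccc4N)cc3)nc(Cl)nc21)OC`: 6.39%
- compound 2 `Nc1ccccc1NC(=O)/C=C/c1ccc(Cn2cnc3c(Nc4cccc(Cl)c4)nc(Cl)nc32)cc1`: 12.9%
- compound 3 `CC(C)n1cnc2c(Nc3cccc(Cl)c3)nc(NCOCc3ccc(/C=C/C(=O)Nc4ccccc4N)cc3)nc21`: 18.5%

All three numbers come from a functional assay on HCT-116 cells (Homo sapiens) for antiproliferative activity, read by CCK-8 assay, with a stated time of 72 h, tested at 2 uM; on this read-out higher numbers stand for a stronger effect at the one concentration tested and lower numbers for a weaker effect. Compound 1 stands lowest of the three. Its nearest neighbour is compound 2, whose number lies within the scatter of compound 1, so the two cannot be ordered. Compound 3 lies beyond the scatter above compound 1, and that is the only gap in the set that counts as real.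

Compound 4 `Nc1ccccc1NC(=O)c1ccc(CNc2nc(Cl)nc3c2ncn3C2CCCC2)cc1` is not yet measured. It departs from compound 1 in one place: cyclopentyl in place of 3,3-dimethoxypropyl on an aromatic nitrogen. The shared core and the rest of compound 1 are kept; only the group on the aromatic nitrogen of the fused system is exchanged, a chain with two hydrogen-bond acceptors giving way to a five-membered non-aromatic ring of carbon only.

Among the measured compounds shown here, no measured pair shows this exchange, so nothing in the set sets its size or sign. The expectation for the step of a number 3.6 percentage points higher from compound 1 to compound 4 (within the scatter) is therefore small, no larger than the scatter, with no clear direction. Compound 4 is estimated at 10%, within 0% to 25%.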

Compound 4, a percentage reported as inhibition, at one concentration (the size of the read-out at that concentration, not a potency): 75.6%
Estimate against measurement, compound 4: 65.6 percentage points below, and the stated range ends below it.
By their numbers in this assay, from the lowest: compounds 1, 2 and 3 (each within the scatter of the next, the first and the last beyond it); then compound 4.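

In this assay, among the compounds shown here, the exchange of 3,3-dimethoxypropyl for cyclopentyl on the aromatic nitrogen gives a number 69.2 percentage points higher from compound 1 to compound 4 (beyond the scatter), the first step that can be read at a single place. With the rest of compound 1 kept, this position alone carries a large change in the read-out at the one concentration tested. The exchange alters the ring, the heavy-atom count and the hydrogen-bond acceptors together, and no evidence on hand separates these or accounts for the step.

Still open, from the compounds shown here alone, is whether a ring is needed here at all: a cyclohexyl ring and an open pentyl chain at this position would tell ring from chain. Also open, going by these compounds, is how a chain ending in an amine or a carboxylic acid would read at the same nitrogen.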